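The compounds below may be only part of what the source reports. "The series", "measured", "known", "first", "only" and "open" are said of these compounds alone.

Within the data shown here, compound 1 `Nc1ncccc1-c1nc2cc(C3CCCC3)cnc2n1-c1ccc(CNC(=O)c2ccccc2)cc1` gives in an in vitro assay on Sf9 cells for binding affinity to RAC-alpha serine/threonine-protein kinase (Homo sapiens), tested at 30 uM (a lower number here means that the compound stabilises the target less, a higher number that the compound stabilises the target more against heat), a shift of 6 degrees C, the highest of the three numbers measured so far. Compound 2 `Nc1ccc(-n2c(-c3cccnc3N)nc3cccnc32)cc1` gives in this assay 4.1 degrees C, a number that lies beyond the scatter below compound 1, and compound 3 `CC(C)(C)c1ccc(-n2c(-c3cccnc3N)nc3cc(Br)cnc32)cc1` gives 0.9 degrees C, further below still. Compound 4 `Nc1ncccc1-c1nc2cc(-c3cccnc3)cnc2n1-c1ccc(CNC(=O)c2ccccc2)cc1` has not yet been measured; it differs from compound 1 in one place: pyridin-3-yl in place of cyclopentyl on an aromatic carbon. Among the measured compounds shown here, no measured pair in this set isolates that change, so its direction is open; a six-membered aromatic ring replaces a five-membered non-aromatic one, and a step of modest size in either direction, or none beyond the scatter, is expected. The expected step from compound 1 to compound 4 is a number 0.50 degrees C lower from compound 1 to compound 4 (within the scatter). Compound 4 is estimated at 5.5 degrees C, between 3 degrees C and 8.5 degrees C.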

Compound 4, shift of the target's melting temperature: 9.2 degrees C
For compound 4 the middle estimate is 3.7 degrees C below the measured one; the whole stated range lies below it.
By their numbers in this assay, from the lowest: compound 3; then compound 2; then compound 1; then compound 4.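

In this assay, among these compounds, the shift is a number 3.2 degrees C higher from compound 1 to compound 4 (beyond the scatter), the first step in this set that isolates this position. It shows that what sits on this aromatic carbon changes the read-out, and that a pyridin-3-yl ring here gives more stabilisation than a cyclopentyl ring on an otherwise identical compound. The compounds shown cannot separate the role of the ring nitrogen from that of the aromatic ring itself, which a plain phenyl ring or a pyridin-4-yl ring at this carbon would address. What lies behind the rise also stays open, as no measurement given here bears on it.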